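Nitro and fluorine placement on the aryl amine

The source may hold more compounds than are shown below. What is called first, only, known or untested is meant among the compounds shown, and "the series" means these compounds.

Two compounds of this series have been run in a functional assay on CCRF-CEM cells (Homo sapiens) for cytotoxicity, in the absence of a further agent; on this read-out lower numbers stand for stronger inhibition and higher numbers for weaker inhibition. Compound 1 `COC(=O)c1ccc(CN(CCCc2c(N)nc(N)nc2O)c2cc(F)cc(F)c2[N+](=O)[O-])cc1` reaches only the ceiling of the assay: compound 1 gives > 100000 nM, which is a limit and not a number, as recorded in the limit of > 100000 nM in this assay, at which 1 of the 2 values shown sits. Within the data shown here, compound 2 `CC(C)(C)OC(=O)CCC(Nc1ccc(CN(CCCc2c(N)nc(N)nc2O)c2cc(F)cc(F)c2[N+](=O)[O-])cc1)C(=O)OC(C)(C)C` is the only compound with a measured number and gives 13000 nM in this assay; it stands alone as the single numerical point.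

Compound 3 `CC(C)(C)OC(=O)CCC(Nc1ccc(CN(CCCc2c(N)nc(N)nc2O)c2ccc([N+](=O)[O-])c(F)c2F)cc1)C(=O)OC(C)(C)C` is the next compound to be run. It differs from compound 2 by 2,3-difluoro-4-nitrophenyl in place of 3,5-difluoro-2-nitrophenyl on an amine nitrogen. The rest of the molecule, including the shared core and the ester-bearing side chain, is kept. Among the measured compounds shown here, no measured pair changes this ring alone, so there is no direct precedent for the step. The two have the same atoms joined differently, and the expected step from compound 2 to compound 3 is a 1.5-fold higher number from compound 2 to compound 3 (0.19 log units; within the scatter), a shift not clearly beyond the usual scatter. Compound 3 is therefore estimated at 20000 nM in this assay, with a range from 5000 nM to 80000 nM. Some chance remains that compound 3 is reported only as a limit.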

Compound 3, half-maximal inhibitory concentration: 24000 nM
Compound 3: middle estimate off by 1.2-fold (0.08 log units), on the low side, and the stated range covers the measured number.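

In this assay, among these compounds, exchanging 3,5-difluoro-2-nitrophenyl for 2,3-difluoro-4-nitrophenyl on the amine nitrogen gives a 1.8-fold higher number from compound 2 to compound 3 (0.27 log units; within the scatter), the first reading of this position. The two compounds have the same atoms joined differently, and on this read-out this pair cannot be told apart, so rearranging the nitro and fluorine substituents on this ring, with the ester-bearing side chain and the shared core kept, leaves no change that can be separated from ordinary repeat variation. Nothing in the data shown accounts for the size of this step, which rests on a single pair.

The compounds shown leave open whether this indifference to the ring pattern extends to other substituents, such as an amine in place of the nitro group, or to a plain phenyl ring carrying neither fluorine nor nitro on the same nitrogen. They also leave open whether the same ring exchange would read the same way with a carboxylic acid in place of the ester groups of the side chain, since both compounds of the pair carry the same esters.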